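Swapping the indole of compound 3 for a phenyl isoxazole

The compounds below may be only part of what the source reports. "The series", "measured", "known", "first", "only" and "open" are said of these compounds alone.

Compound 1 `O=C(Nc1c(O)cccc1-c1nc2c(C(=O)O)cccc2o1)c1ncccc1F` gives 204000 nM
Compound 2 `O=C(Nc1c(O)cccc1-c1nc2c(C(=O)O)cccc2o1)c1cccc(Cl)c1` gives 143000 nM
Compound 3 `O=C(Nc1c(O)cccc1-c1nc2c(C(=O)O)cccc2o1)c1cc2ccccc2[nH]1` gives 212000 nM

These three values come from an ADME assay on L6 cells (Rattus norvegicus) for cytotoxicity (on this read-out higher numbers stand for weaker inhibition and lower numbers for stronger inhibition), and belong to compounds that differ only in the group on a carbonyl carbon. Compound 3 cannot be separated from the other two, as the steps show: a 1.0-fold higher number from compound 1 to compound 3 (0.02 log units; within the scatter) and a 1.5-fold higher number from compound 2 to compound 3 (0.17 log units; within the scatter) both stay within the scatter. Compound 4 `O=C(Nc1c(O)cccc1-c1nc2c(C(=O)O)cccc2o1)c1cc(-c2ccccc2)on1` has not yet been measured in this assay and differs from compound 3 at that same place. The change is 5-phenyl-1,2-oxazol-3-yl in place of 1H-indol-2-yl on a carbonyl carbon and the rest of the molecule stays as it is.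

The three measured steps all bear on this swap, since each exchanges one group on that carbonyl carbon for another. The third of them, a 1.4-fold lower number from compound 1 to compound 2 (0.15 log units; within the scatter), is also within the scatter. Among the measured compounds shown here, none of the three compounds carries 5-phenyl-1,2-oxazol-3-yl, so the data offer no direct precedent for it. With every swap so far this small, no shift beyond the scatter is expected, in either direction, and the estimated step is a 1.2-fold lower number from compound 3 to compound 4 (0.07 log units; within the scatter) overall. Compound 4 is therefore expected at about 180000 nM (estimated range 100000 nM to 300000 nM).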

Compound 4, half-maximal inhibitory concentration: 141000 nM
For compound 4 the middle estimate is 1.3-fold (0.11 log units) above the measured one, within the range that was stated.
By their numbers in this assay, from the lowest: compounds 4, 2, 1 and 3 (each within the scatter of the next).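

In this assay, the exchange of 1H-indol-2-yl for 5-phenyl-1,2-oxazol-3-yl gives up the hydrogen-bond donor of the leaving group and brings in hydrogen-bond acceptors and more heavy atoms, yet a 1.5-fold lower number from compound 3 to compound 4 (0.18 log units; within the scatter) stays within the scatter. The new group also cannot be separated from the other two groups on the carbonyl carbon, as a 1.0-fold lower number from compound 2 to compound 4 (0.01 log units; within the scatter) and a 1.4-fold lower number from compound 1 to compound 4 (0.16 log units; within the scatter) show, so all four compounds now lie within the scatter of their neighbours in the order of their numbers. Nothing available explains this flat picture at the position.

From the compounds shown here alone, all four groups at this place are aromatic, so it remains open whether a saturated group such as a piperidine ring or a longer alkyl chain on the carbonyl carbon, or a phenyl ring carrying an amine or a carboxylic acid, would give a step beyond the scatter. Since the rest of the molecule is the same throughout, these compounds also say nothing about how changes to the shared core would act on this read-out.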